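This account rests on a few compounds, and the source may have more. Where it says the series, first, only, none or still open, it means among the compounds named here.

Measured so far:
compound 1 `N/C(=N\O)c1ccc(C(=O)CS(=O)(=O)c2ccccc2)cc1` — > 125000 nM
compound 2 `CC1(Cc2ccccc2)CC(S(=O)(=O)c2ccc(Nc3ccc(/C(N)=N/O)cc3)cc2)=C(c2ccc(/C(N)=N/O)cc2)O1` — 47600 nM
compound 3 `N/C(=N\O)c1ccc(/C=C/c2ccc(S(=O)(=O)C3=C(c4ccc(/C(N)=N/O)cc4)OC(c4ccccc4)(c4ccccc4)C3)cc2)cc1` — > 10000 nM

Within the data shown here, in an ADME assay on THP-1 cells (Homo sapiens) for cytotoxicity, read by flow cytometry, with a stated time of 72 h (a higher number here means a weaker inhibitor, a lower number a stronger inhibitor), compound 2 gives 47600 nM, the only actual number in the set. For compound 1 the entry > 125000 nM is a limit of the assay. For compound 3 the entry > 10000 nM is likewise a limit. Among the measured compounds shown here, no step between measured compounds is available.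

Compound 4 `CC1(Cc2ccccc2)CC(S(=O)(=O)c2ccc(/C=C/c3ccc(/C(N)=N/O)cc3)cc2)=C(c2ccc(/C(N)=N/O)cc2)O1` has not been measured. Relative to compound 2 the change is a group of 12 heavy atoms (9 carbon, 2 nitrogen, 1 oxygen; one six-membered aromatic ring of carbon only) in place of a group of 11 heavy atoms (7 carbon, 3 nitrogen, 1 oxygen; one six-membered aromatic ring of carbon only), on an aromatic carbon. Compound 3 carries the same entering group and sits at a limit. No movement beyond the scatter is expected; the expected step of a 1.1-fold higher number from compound 2 to compound 4 (0.02 log units; within the scatter) is small. Compound 4 is estimated at 50000 nM, range 15000 nM to 150000 nM.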

Compound 4, half-maximal inhibitory concentration: > 50000 nM
Compound 4: only a limit was reported; the forecaster's own chance of this, stated with the estimate: 40%; the middle value sits exactly at the limit.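

In this assay compound 4 is reported only as a limit: the limit of > 50000 nM in this assay, at which 1 of the 4 values shown sits. At this place, on an aromatic carbon para to a large group, the group of 12 heavy atoms in place of the group of 11 heavy atoms gives an at least 1.0-fold higher number from compound 2 to compound 4 (0.02 log units; that floor lies within the scatter). The change therefore brings no lower number, and only a floor is available for its size.

Going by these compounds, how far the true value of compound 4 lies past its limit stays open. Also open, on these data alone, is what an amine or a carboxylic acid on this aromatic carbon would give in this assay.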